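The source may hold more compounds than are shown below. What is called first, only, known or untested is meant among the compounds shown, and "the series" means these compounds.

Compound 1 `ClCC#CCSc1cnc2ccccc2c1Cl`: 3.7 ug/mL
Compound 2 `OCC#CCSc1cnc2ccccc2c1[Se]CC#CCCl`: 2.6 ug/mL

Both compounds were tested in a functional assay on CCRF-CEM cells (Homo sapiens) for antiproliferative activity, with a stated time of 72 h; a lower number here means a stronger inhibitor, a higher number a weaker inhibitor. Of the two numbers shown, compound 2 gives the lowest, at 2.6 ug/mL, while compound 1 gives 3.7 ug/mL; the gap between them lies within the usual scatter of this assay, so the two values cannot be told apart with confidence.

Compound 3 `OCC#CCSc1cnc2ccccc2c1Cl` is the next compound in the series and has not yet been measured. It is derived from compound 2 by a single change: one chlorine atom in place of a group of 6 heavy atoms (4 carbon, 1 chlorine, 1 selenium; no ring), on an aromatic carbon. The remaining part of the molecule, including the shared core and the hydroxyl-bearing chain on the sulfur, is kept as in compound 2.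

Going by the values given here, no step between measured compounds is available to guide the expectation, since compound 1 and compound 2 differ in more than one place. The step from compound 2 to compound 3 is therefore expected to be small, a 1.2-fold higher number from compound 2 to compound 3 (0.06 log units; within the scatter), not beyond the scatter of this assay in either direction. On this basis compound 3 is estimated at 3 ug/mL, with a range from 1.3 ug/mL to 7 ug/mL.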

Compound 3, concentration for 50% inhibition: 4.1 ug/mL
Estimate against measurement, compound 3: 1.4-fold (0.14 log units) below, within the range that was stated.
By their numbers in this assay, from the lowest: compounds 2, 1 and 3 (each within the scatter of the next).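

In this assay, putting one chlorine atom in place of the group of 6 heavy atoms (4 carbon, 1 chlorine, 1 selenium) on the aromatic carbon opposite the ring nitrogen gives a 1.6-fold higher number from compound 2 to compound 3 (0.20 log units; within the scatter), so even a swap this large in size at this position yields two values that cannot be told apart. The second readable step concerns the chain on the sulfur: hydroxy in place of chloro on the saturated chain carbon bound to a triple-bonded carbon gives a 1.1-fold higher number from compound 1 to compound 3 (0.04 log units; within the scatter), and these two values cannot be told apart either. Nothing available accounts for how closely these values agree, and the numbers alone offer no explanation.

The compounds shown leave open whether an amine or a methoxy group on that aromatic carbon, or an amine or a longer chain in place of the hydroxy group, would give a value beyond the scatter. With three compounds that all lie within the scatter of one another, neither position can yet be said to matter or not to matter for this activity.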